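Ring size of the amine on the core of compound 1

The source may report more compounds than this note shows. Statements on the series, on what has been measured and on what is new or still open speak of the compounds shown alone.

Compound 1 `c1cc(N2CCCCC2)nc(Nc2ccc(Oc3ncnc4sccc34)cc2)n1` is the reference point of this set. In a functional assay on MDA-MB-231 cells (Homo sapiens) for inhibition, read by MTT assay, with a stated time of 72 h, tested at 20 uM (on this read-out lower numbers stand for less inhibition and higher numbers for more inhibition at the one concentration tested (going by the name of the read-out)), compound 1 gives 40.4%, the second highest of the three numbers measured. Its nearest neighbour is compound 3 `CN(c1ccc(Oc2ncnc3sccc23)cc1)c1nccc(N2CCCCC2)n1`, which gives 29.3%. The furthest is compound 2 `CNC(=O)c1cc(Oc2ccc(Nc3nccc(N4CCCCC4)n3)cc2)ccn1`, which gives 52.3%.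

Two steps from compound 1 are known. a number 11.9 percentage points higher from compound 1 to compound 2 (beyond the scatter). a number 11.1 percentage points lower from compound 1 to compound 3 (beyond the scatter). Both steps are beyond the scatter and modest in size, and both concern parts of the molecule other than the non-aromatic ring.

Compound 4 `c1cc(N2CCCC2)nc(Nc2ccc(Oc3ncnc4sccc34)cc2)n1` differs from compound 1 in a single place: pyrrolidin-1-yl in place of piperidin-1-yl on an aromatic carbon. Neither measured step bears on this change. The step to compound 2 alters the group on an oxygen on an aromatic ring, the step to compound 3 alters a hydrogen on a nitrogen on an aromatic ring, and the piperidin-1-yl group is kept in all three measured compounds. Within the data shown here, no measured step on this ring exists, so the expectation for this assay is a change of no more than the scatter, in no firm direction. The step expected is a number 0.4 percentage points lower from compound 1 to compound 4 (within the scatter). Compound 4 is estimated at 40%, within the range 25% to 55%.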

Compound 4, a percentage reported as inhibition, at one concentration (the size of the read-out at that concentration, not a potency): 24.7%
Compound 4: the middle estimate sits 15.3 percentage points above what was measured; measured number outside the range, below it.
By their numbers in this assay, from the lowest: compounds 4 and 3 (each within the scatter of the next); then compound 1; then compound 2.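

The position carrying the non-aromatic amine is not neutral in this assay: a number 15.7 percentage points lower from compound 1 to compound 4 (beyond the scatter), so pyrrolidin-1-yl in place of piperidin-1-yl on this aromatic carbon moves the read-out beyond the scatter, and the step is modest, as are the two earlier steps elsewhere on the molecule. Compounds 1, 2 and 3 all keep piperidin-1-yl and so gave no reading on this ring, whereas this pair shows that the ring size of the amine matters here, with the five-membered ring giving the lower inhibition at the one concentration tested. No measurement at hand accounts for this difference.

Among these compounds, with only two ring sizes compared on a single background, this pair fixes a direction for that one change and no trend across ring sizes, and it gives no potency. From the compounds shown here alone, it remains open how a morpholin-4-yl ring, a seven-membered azepan-1-yl ring or an open-chain dimethylamino group would read on this carbon, and whether the same change would hold with the groups of compound 2 or compound 3 in place.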